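Replacing chlorine by fluorine on the pendant aryl ring

This account rests on a few compounds, and the source may have more. Where it says the series, first, only, none or still open, it means among the compounds named here.

Going by the values given here, compound 3 `Clc1ccc(-c2csc(N/N=C/c3ccc(N4CCCC4)cc3)n2)c(Cl)c1` is the only member of this small set with a number in an assay on isolated protein for inhibition of Amine oxidase [flavin-containing] B (Homo sapiens), read by fluorescence and Amplex Red, with a stated time of 30 min; on this read-out higher numbers stand for weaker inhibition and lower numbers for stronger inhibition: compound 3 gives 131000 nM. Compound 1 `Cc1ccc(-c2csc(N/N=C/c3ccc(N4CCCC4)cc3)n2)cc1` reaches only a limit in this assay, giving > 100000 nM. Compound 2 `Brc1ccc(-c2csc(N/N=C/c3ccc(N4CCCC4)cc3)n2)cc1` likewise stops at a limit, giving > 1000000 nM. Among the comparisons, an at least 7.6-fold lower number from compound 2 to compound 3 (0.88 log units; beyond the scatter), whereas a step that the two limits leave unreadable from compound 1 to compound 2 and a step that the limit leaves unreadable from compound 1 to compound 3. Compound 4 `Fc1ccc(-c2csc(N/N=C/c3ccc(N4CCCC4)cc3)n2)c(F)c1` differs from compound 3 by 2,4-difluorophenyl in place of 2,4-dichlorophenyl on an aromatic carbon. The one readable step, from a bromo-bearing to a dichloro-bearing aryl ring, is the only guide, and it concerns a halogen swap on the same ring; whether a further halogen swap helps or hurts is not shown by these compounds, since no fluoro-bearing analogue has been measured. Compound 4 is therefore expected to land near compound 3 or somewhat weaker. The expected step is a 2.3-fold higher number from compound 3 to compound 4 (0.36 log units; beyond the scatter), a modest move toward weaker inhibition, with a real chance that only a limit is reported. The estimate for compound 4 is 300000 nM, within 80000 nM to 1200000 nM.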

Compound 4, half-maximal inhibitory concentration: 141000 nM
For compound 4 the middle estimate is 2.1-fold (0.33 log units) above the measured one; the range from low to high includes it.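

In this assay, going by these compounds alone, the change from 2,4-dichlorophenyl to 2,4-difluorophenyl gives a 1.1-fold higher number from compound 3 to compound 4 (0.03 log units; within the scatter), so at this place on the shared core the two halogen pairs cannot be told apart, which the earlier compounds could not show. The difluoro ring also keeps the distance from the bromo compound seen for the dichloro ring, with an at least 7.0-fold lower number from compound 2 to compound 4 (0.85 log units; beyond the scatter). The step from compound 1 cannot be read, because compound 1 stops at a limit: the limit of > 100000 nM in this assay, at which 1 of the 4 values shown sits.

Going by these compounds, it remains open whether a ring with a single halogen, such as 4-chlorophenyl or 4-fluorophenyl, would read like compound 3 and compound 4 or would stop at a limit like compound 2. Also open, on these data alone, is whether a methoxy group or an amine on this ring would move the number.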